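A Hydroxyphenyl Swap on Compound 2

This account rests on a few compounds, and the source may have more. Where it says the series, first, only, none or still open, it means among the compounds named here.

Of the compounds shown here, two have so far been tested in a functional assay on MCF7 cells (Homo sapiens) for antiproliferative activity, read by sulforhodamine B assay, with a stated time of 48 h; on this read-out lower numbers stand for stronger inhibition and higher numbers for weaker inhibition. Compound 1 `COc1cccc(/C=C/C(=O)/C=C(O)/C=C/c2cccc(OC)c2OC)c1OC` reaches only a limit of the assay, > 50000 nM. Going by the values given here, compound 2 `COc1ccc(/C=C/C(=O)C(=Cc2ccc(O)c(F)c2)C(=O)/C=C/c2ccc(OC)cc2OC)c(OC)c1` gives 5450 nM, the only actual number available, so it has no measured neighbour against which its standing can be judged.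

The next compound to be tested is compound 3 `COc1ccc(/C=C/C(=O)C(=Cc2ccc(OC)c(O)c2)C(=O)/C=C/c2ccc(OC)cc2OC)c(OC)c1`. It keeps the shared core of compound 2 and changes one group, on a double-bonded chain carbon bound to a double-bonded chain carbon, where 3-hydroxy-4-methoxyphenyl takes the place of 3-fluoro-4-hydroxyphenyl (3-hydroxy-4-methoxyphenyl in place of 3-fluoro-4-hydroxyphenyl on a double-bonded chain carbon bound to a double-bonded chain carbon). Among the compounds with values here, no measured pair shows what such a swap does in this assay. The expectation therefore rests on compound 2, at 5450 nM, and on the rest of the structure staying the same.

The expected step of a 1.2-fold lower number from compound 2 to compound 3 (0.08 log units; within the scatter) is small, within the usual scatter, and no firm direction is expected. For compound 3, the estimated half-maximal inhibitory concentration is 4500 nM, with an expected range of 1500 nM to 14000 nM.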

Compound 3, half-maximal inhibitory concentration: 1600 nM
Compound 3: the middle estimate sits 2.8-fold (0.45 log units) above what was measured, within the range that was stated.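

In this assay, going by these compounds alone, the place on a double-bonded chain carbon bound to a double-bonded chain carbon proves sensitive to the group it carries: 3-hydroxy-4-methoxyphenyl in place of 3-fluoro-4-hydroxyphenyl gives a 3.4-fold lower number from compound 2 to compound 3 (0.53 log units; beyond the scatter), the first measured step and one that moves toward stronger inhibition. The swap removes the fluoro group, brings in a methoxy group and gives the hydroxy group a different number in the name, all at once, so this single pair cannot show which part of the change carries the step. No measurement shown here bears on why the swap has this effect.

Going by these compounds, it remains open whether 4-hydroxy-3-methoxyphenyl, 3,4-dimethoxyphenyl or 3-fluoro-4-methoxyphenyl at this place would separate the contributions of the hydroxy, methoxy and fluoro groups, and whether an amine or a carboxylic acid would be tolerated there. Whether the same swap gives a similar step on a different core also stays unanswered.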